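The source may hold more compounds than are shown below. What is called first, only, known or untested is meant among the compounds shown, and "the series" means these compounds.

Among the compounds with values here, in a functional assay on HT-29 cells (Homo sapiens) for antiproliferative activity, read by sulforhodamine B assay, with a stated time of 72 h (a higher number here means a weaker inhibitor, a lower number a stronger inhibitor), compound 3 `O=C(Cn1nc(Cc2ccccc2)c2ccccc2c1=O)Nc1cccc(Cl)c1` gives 3680 nM, the lowest of the two true numbers so far. Compound 1 `O=C(Cn1nc(-c2ccccc2)c2ccccc2c1=O)Nc1cccc(C(F)(F)F)c1`, which also carries 3-(trifluoromethyl)phenyl, gives a higher 41200 nM. For compound 2 `COc1ccc(NC(=O)Cn2nc(Cc3ccccc3)c3ccccc3c2=O)cc1`, the reading of > 100000000 nM is a limit of the assay, not a number. Compound 4 `O=C(Cn1nc(Cc2ccccc2)c2ccccc2c1=O)Nc1cccc(C(F)(F)F)c1`, still unmeasured, has trifluoromethyl in place of chloro on an aromatic carbon. Within the data shown here, the one measured step, an at least 27000-fold lower number from compound 2 to compound 3 (4.43 log units; beyond the scatter), was large, but it starts from that limit and swaps different groups, so it bears only loosely on this change. A small move toward a higher number in this assay is expected, possibly within the scatter. The expected step is a 1.6-fold higher number from compound 3 to compound 4 (0.21 log units; within the scatter). For compound 4, the estimated value is 6000 nM, with an expected range of 1500 nM to 25000 nM.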

Compound 4, half-maximal inhibitory concentration: 61000 nM
Beside the measured number, compound 4's estimate is 10-fold (1.01 log units) below it; measured number above the stated range.
By their numbers in this assay, from the lowest: compound 3; then compounds 1 and 4 (each within the scatter of the next). At a limit, above all of these: compound 2.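

In this assay, within the data shown here, trifluoromethyl in place of chloro on an aromatic carbon gives a 17-fold higher number from compound 3 to compound 4 (1.22 log units; beyond the scatter) and so matters far more than the earlier compounds could show. With trifluoromethyl held constant, benzyl and phenyl on the core cannot be told apart, as a 1.5-fold higher number from compound 1 to compound 4 (0.17 log units; within the scatter) lies within the scatter. 3-(Trifluoromethyl)phenyl in place of 4-methoxyphenyl on an amide-type nitrogen gives an at least 1600-fold lower number from compound 2 to compound 4 (3.21 log units; beyond the scatter) and this step starts from a limit. The reading for compound 2 is a limit of the assay and not a number: the limit of > 100000000 nM in this assay, at which 1 of the 4 values shown sits.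

Going by these compounds, it remains open whether chloro would give the same gain with phenyl on the core. On these data alone, how an amine or a carboxylic acid would behave in place of chloro also remains open.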